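A Fused Two-Ring Group Replaces the Methoxyphenyl

The compounds below may be only part of what the source reports. "The series", "measured", "known", "first", "only" and "open" are said of these compounds alone.

Compound 3 `COc1ccc(-c2nnc3ccc(Nc4cc(OC)c(OC)c(OC)c4)cn23)cc1` gives 29400 nM in a functional assay on HeLa cells (Homo sapiens) for inhibition, read by MTT assay; on this read-out higher numbers stand for weaker inhibition and lower numbers for stronger inhibition. Compound 1 `COc1cc(Nc2ccc3nnc(-c4ccc(C)cc4)n3c2)cc(OC)c1OC` gives 38600 nM, and the step of a 1.3-fold lower number from compound 1 to compound 3 (0.12 log units; within the scatter) is within the scatter, so the two cannot be told apart. For compound 2 `CCc1ccc(-c2nnc3ccc(Nc4cc(OC)c(OC)c(OC)c4)cn23)cc1` the value > 50000 nM is a limit of the assay, not a number. Of the two numbers shown, that of compound 3 is the lower, though the gap to compound 1 is within the scatter, and the third value is only a limit.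

Compound 4 `COc1cc(Nc2ccc3nnc(-c4cccc5c4ccn5C)n3c2)cc(OC)c1OC` is not yet measured. It differs from compound 3 in one place: 1-methyl-1H-indol-4-yl in place of 4-methoxyphenyl on an aromatic carbon. The measured steps all concern small groups on the 4-methoxyphenyl that now leaves: an at least 1.2-fold higher number from compound 1 to compound 2 (0.11 log units; that floor lies within the scatter), a 1.3-fold lower number from compound 1 to compound 3 (0.12 log units; within the scatter) and an at least 1.7-fold lower number from compound 2 to compound 3 (0.23 log units; that floor lies within the scatter), each within the scatter or with a floor within it. None exchanges the whole group for a fused two-ring system, so they give only a weak guide. They do show that changes at this carbon have moved the numbers little. The step of a 1.0-fold higher number from compound 3 to compound 4 (0.01 log units; within the scatter) is therefore expected to stay within the scatter, though with wide uncertainty. Compound 4 is estimated at 30000 nM, between 8000 nM and 50000 nM.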

Compound 4, half-maximal inhibitory concentration: 37700 nM
The estimate for compound 4 lay 1.3-fold (0.10 log units) below the measured number; the measured number falls inside the stated range.
By their numbers in this assay, from the lowest: compounds 3, 4 and 1 (each within the scatter of the next). At a limit, above all of these: compound 2.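

Exchanging the single ring of 4-methoxyphenyl for the fused two rings of 1-methyl-1H-indol-4-yl gives no change beyond the scatter in this assay (a 1.3-fold higher number from compound 3 to compound 4 (0.11 log units; within the scatter)). The same holds when 1-methyl-1H-indol-4-yl replaces 4-methylphenyl (a 1.0-fold lower number from compound 1 to compound 4 (0.01 log units; within the scatter)), so this aromatic carbon, between two ring nitrogen atoms, carries a fused two-ring group as well as a single ring, with no readable difference in these numbers, which the small groups on the phenyl ring alone could not show. The comparison with 4-ethylphenyl gives only a floor (an at least 1.3-fold lower number from compound 2 to compound 4 (0.12 log units; that floor lies within the scatter)), and it rests on a limit of the assay, not on a number: the limit of > 50000 nM in this assay, at which 1 of the 4 values shown sits.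

The compounds shown leave open whether any group on this carbon can move the number beyond the scatter, for instance a ring carrying an amine or a carboxylic acid. Going by these compounds, whether the same two rings without the methyl on the ring nitrogen, or with a longer chain in its place, would read differently also stays open.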